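Swapping the aminophenyl in a trimethoxyphenyl pyrazole chalcone

This account rests on a few compounds, and the source may have more. Where it says the series, first, only, none or still open, it means among the compounds named here.

Compound 1 `COc1cc(-c2cc(/C=C/C(=O)c3ccc(N)cc3)[nH]n2)cc(OC)c1OC` was tested in a functional assay on BT-549 cells (Homo sapiens) for inhibition, read by sulforhodamine B assay, with a stated time of 48 h (a higher number here means that more compound is tolerated, a lower number that less compound is tolerated), where compound 1 gives 5760 nM. Two close relatives were measured alongside it. Compound 2 `COc1ccc(-c2cc(/C=C/C(=O)c3ccc(N)cc3)[nH]n2)cc1OC` gives 5770 nM in this assay, and compound 3 `COc1ccc(-c2cc(/C=C/C(=O)c3cc(OC)c(OC)c(OC)c3)[nH]n2)cc1OC` gives 6320 nM. The only single-point step among these three, a 1.0-fold higher number from compound 1 to compound 2 (0.00 log units; within the scatter), shows that removing a methoxy from the aryl ring attached to the shared core leaves the number essentially unchanged. Compound 1 thus stands together with compound 2 and compound 3, all three within the scatter of one another.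

Compound 4 `COc1cc(-c2cc(/C=C/C(=O)c3ccc(F)c(F)c3)[nH]n2)cc(OC)c1OC` is the next candidate. 3,4-difluorophenyl in place of 4-aminophenyl on a carbonyl carbon The change sits on the carbonyl carbon, a place the measured step from compound 1 to compound 2 does not touch. The closest guide is compound 3, which carries a trimethoxyphenyl on that same carbonyl carbon in place of the aminophenyl of compound 1; its value and that of compound 1 lie within the scatter. So far, then, varying the aryl group on the carbonyl carbon has not moved the number beyond the scatter. For compound 4 the step of a 1.0-fold higher number from compound 1 to compound 4 (0.02 log units; within the scatter) is therefore expected to stay within the scatter. Compound 4 is expected to give about 6000 nM, with a range from 2500 nM to 14000 nM.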

Compound 4, concentration lethal to 50% of the cells: 79500 nM
Compound 4: middle estimate off by 13-fold (1.12 log units), on the low side; measured number outside the range, above it.
By their numbers in this assay, from the lowest: compounds 1, 2 and 3 (each within the scatter of the next); then compound 4.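

In this assay the group on the carbonyl carbon proves able to move the number a long way: replacing 4-aminophenyl with 3,4-difluorophenyl gives a 14-fold higher number from compound 1 to compound 4 (1.14 log units; beyond the scatter), so much more of the compound must be present to reach the same read-out. This is the only step shown that lies beyond the scatter, whereas the loss of a methoxy group in a 1.0-fold higher number from compound 1 to compound 2 (0.00 log units; within the scatter) left the number in place, so this carbonyl-side aryl group is the one place in these compounds where a single change is seen to matter. No measurement at hand accounts for the shift.

The swap removes the amine and adds two fluorines in a single step, so these compounds cannot show whether keeping the amine or avoiding the fluorines matters more. A plain phenyl group, or a phenyl group carrying a single fluorine, a hydroxyl group or a dimethylamino group, on the same carbonyl carbon would help to separate those two parts of the change.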